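This account rests on a few compounds, and the source may have more. Where it says the series, first, only, none or still open, it means among the compounds named here.

Within the data shown here, only two compounds sharing one core have been measured so far in a functional assay on HL-60 cells (Homo sapiens) for cytotoxicity, read by CCK-8 assay, with a stated time of 24 h; a lower number here means a stronger inhibitor, a higher number a weaker inhibitor. In that test, compound 1 `C=CC(=O)N1C(=O)CC(c2ccc(C(F)(F)F)cc2)Sc2ccccc21` gives 106000 nM and compound 2 `C=CC(=O)N1C(=O)CC(c2ccc(C)cc2)Sc2ccccc21` gives 94400 nM. These two values lie within the scatter of each other, so compound 2 cannot be ranked apart from compound 1. The next compound, compound 3 `C=CC(=O)N1C(=O)CC(c2ccc(OC)cc2)Sc2ccccc21`, has methoxy in place of methyl on an aromatic carbon, para to a large group: methoxy in place of methyl on an aromatic carbon. Among the measured compounds shown here, the one measured step that bears on this change is a 1.1-fold lower number from compound 1 to compound 2 (0.05 log units; within the scatter), which put methyl in place of trifluoromethyl on an aromatic carbon and stayed within the scatter. That single step is thin evidence, but it gives no reason to expect a step beyond the scatter in this assay. The expected change is a 1.0-fold lower number from compound 2 to compound 3 (0.02 log units; within the scatter), an estimate with no clear direction. For compound 3 the estimated value is 90000 nM, within an expected range of 45000 nM to 170000 nM.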

Compound 3, half-maximal inhibitory concentration: 92100 nM
Estimate against measurement, compound 3: 1.0-fold (0.01 log units) below; the measured number falls inside the stated range.
By their numbers in this assay, from the lowest: compounds 3, 2 and 1 (each within the scatter of the next).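

In this assay, methoxy in place of methyl on this aromatic carbon, para to a large group, gives a 1.0-fold lower number from compound 2 to compound 3 (0.01 log units; within the scatter), and methoxy in place of trifluoromethyl gives a 1.2-fold lower number from compound 1 to compound 3 (0.06 log units; within the scatter). This position has now carried three different groups, and methoxy brings a hydrogen-bond acceptor that methyl lacks, yet all three compounds remain within the scatter of one another in this test. No measurement is available to explain why these swaps leave the values indistinguishable.

The compounds shown leave open whether an amine, a carboxylic acid or a longer chain at this position would produce a step beyond the scatter. They also leave open whether a change elsewhere on the shared core would do so.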